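This account rests on a few compounds, and the source may have more. Where it says the series, first, only, none or still open, it means among the compounds named here.

Measured in a functional assay on Hep 3B2 cells (Homo sapiens) for cytotoxicity, read by MTT assay, with a stated time of 6 days; on this read-out lower numbers stand for stronger inhibition and higher numbers for weaker inhibition:
Compound 1 `Cc1ccc2c(c1)OCC(=O)N2Cc1cn(Cc2ccccc2)nn1`: > 100000 nM
Compound 2 `CCC1Oc2ccccc2N(Cc2cn(Cc3ccccc3)nn2)C1=O`: > 100000 nM

Neither entry is a number. Compound 1 stands at a limit of the assay, > 100000 nM. Compound 2 stands at a limit too, > 100000 nM, so its place in the series is known only as that limit. For the measured compounds named here, the whole record in this assay so far is the limit of > 100000 nM in this assay, at which 2 of the 2 values shown sit.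

Compound 3 `CCCC1Oc2ccccc2N(Cc2cn(Cc3ccccc3)nn2)C1=O` differs from compound 2 by one change, ethyl to propyl: methyl in place of hydrogen on a saturated chain carbon, two bonds along the chain from a saturated ring carbon. In words, this is methyl in place of hydrogen on a saturated chain carbon, two bonds along the chain from a saturated ring carbon.

Going by the values given here, no measured pair shows what such a change does, so the expectation in this assay rests on the two limits alone. No step beyond the usual scatter is expected, in either direction, and another limit is the likeliest report. The step expected is a number no higher from compound 2 to compound 3 (the limit leaves the size open). Compound 3 is estimated at 100000 nM, with an expected range from 50000 nM to 200000 nM.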

Compound 3, half-maximal inhibitory concentration: 61800 nM
Compound 3: middle estimate off by 1.6-fold (0.21 log units), on the high side; measured number inside the range.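

In this assay, the change from ethyl to propyl, methyl in place of hydrogen on a saturated chain carbon, two bonds along the chain from a saturated ring carbon, gives an at least 1.6-fold lower number from compound 2 to compound 3 (0.20 log units; that floor lies within the scatter). For the compounds shown here, compound 3 thereby brings the first actual number, 61800 nM, showing that a compound with this chain can be read inside the range of the assay. The step as printed does not by itself establish a change beyond the scatter. The earlier compounds gave no number at all, only a limit, and that limit still accounts for most of the record: the limit of > 100000 nM in this assay, at which 2 of the 3 values shown sit.

The compounds shown leave open how large the step from ethyl to propyl truly is, and whether a longer chain such as butyl would carry the number further down in this assay. They also leave open what an amine or a carboxylic acid at the end of the propyl chain would do at this place.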